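The source may hold more compounds than are shown below. What is called first, only, known or untested is meant among the compounds shown, and "the series" means these compounds.

Compound 1 `Nc1cc(N)c2nc(-c3ccccc3)c(NCc3ccc(F)cc3)nc2c1` is examined in a functional assay on ACHN cells (Homo sapiens) for inhibition, read by sulforhodamine B assay, with a stated time of 48 h (on this read-out higher numbers stand for lower toxicity in this test and lower numbers for higher toxicity in this test), where compound 1 gives 5620 nM. Against the one other measured compound, compound 2 `COc1ccc(CNc2nc3cc(N)cc(N)c3nc2-c2ccccc2)cc1`, which in this assay gives 75900 nM, compound 1 stands with the lowest of the two numbers, the step being a 14-fold higher number from compound 1 to compound 2 (1.13 log units; beyond the scatter). The unmeasured compound 3 `Nc1cc(N)c2nc(-c3ccccc3)c(Sc3ccc(F)cc3)nc2c1` differs from compound 1 by (4-fluorophenyl)sulfanyl in place of (4-fluorobenzyl)amino on an aromatic carbon. For the measured compounds named here, the measured step from compound 1 to compound 2 concerns the substituent on the pendant ring, not the link between that ring and the core, so no measured step bears directly on the change to compound 3, and the size of the step in this assay is not anchored by the data; the expected step is a 1.4-fold higher number from compound 1 to compound 3 (0.15 log units; within the scatter), that is, no change beyond the scatter but with wide uncertainty. Compound 3 is therefore estimated at 8000 nM in this assay, in a range from 2000 nM to 40000 nM.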

Compound 3, concentration lethal to 50% of the cells: < 100000 nM
Compound 3 ended at the assay's limit (the forecaster's own chance of this, stated with the estimate: 10%); the middle value lies beyond the limit too.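

Compound 3 ended at a limit of the assay rather than at a number, so the step from compound 1 to compound 3 cannot be read in this assay: the limit of < 100000 nM in this assay, at which 1 of the 3 values shown sits.

The compounds shown leave open whether (4-fluorophenyl)sulfanyl in place of (4-fluorobenzyl)amino changes the number in this assay at all, and in which direction.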